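A few compounds are considered here, and "the series" means these few. Any claim that something is new, unique, unknown or untested is made for them only; others in the source may bear on it.

Measured compounds:
- Compound 1, `O=C(CCCCCCn1cc(Nc2ncc3ccn(Cc4ccccc4)c3n2)cn1)NO`: 12.5 nM
- Compound 2, `O=C(CCCCCCn1cc(Nc2ncc3ccn(Cc4cccc(Cl)c4)c3n2)cn1)NO`: 36.8 nM

Both were tested in an assay on isolated protein for inhibition of protein deacetylase HDAC6 (Homo sapiens), with a stated time of 60 min; a higher number here means a weaker inhibitor, a lower number a stronger inhibitor. Among the measured compounds shown here, compound 2 carries the higher of the two numbers, with compound 1 a 2.9-fold higher number from compound 1 to compound 2 (0.47 log units; beyond the scatter): the only step measured so far, and a modest one. Compound 3, `COc1cccc(Cn2ccc3cnc(Nc4cnn(CCCCCCC(=O)NO)c4)nc32)c1`, has not yet been measured; it differs from compound 2 by methoxy in place of chloro on an aromatic carbon. For the measured compounds named here, no measured step swaps chloro for methoxy, so the only guide is that the bare ring of compound 1 gives the lower number and chloro on that ring raises it. A methoxy group could plausibly land anywhere in that span. The expectation for compound 3 is therefore a number near that of compound 2, with a chance of a small move back toward compound 1, so the estimated step is a 1.5-fold lower number from compound 2 to compound 3 (0.17 log units; within the scatter). Compound 3 is expected to give about 25 nM, with a likely range from 10 nM to 60 nM.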

Compound 3, half-maximal inhibitory concentration: 28.8 nM
Compound 3: middle estimate off by 1.2-fold (0.06 log units), on the low side; the measured number falls inside the stated range.
By their numbers in this assay, from the lowest: compound 1; then compounds 3 and 2 (each within the scatter of the next).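

In this assay, methoxy in place of chloro on this aromatic carbon gives a 1.3-fold lower number from compound 2 to compound 3 (0.11 log units; within the scatter), so the two groups cannot be told apart here, even though methoxy brings a hydrogen-bond acceptor and chloro none. The rise seen with chloro is thus not unique to that group: methoxy in place of hydrogen gives a 2.3-fold higher number from compound 1 to compound 3 (0.36 log units; beyond the scatter), and among these three compounds the bare benzyl of compound 1 keeps the lowest number. No measurement available here explains why the two groups match.

From the compounds shown here alone, it remains open whether a much smaller group such as fluoro, or a charged one such as an amine or a carboxylic acid, would follow the same trend at this position. The effect of placing chloro or methoxy on another carbon of the ring is also still unknown.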